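Trimming One Fluorine from the Amide Aryl Group

A few compounds are considered here, and "the series" means these few. Any claim that something is new, unique, unknown or untested is made for them only; others in the source may bear on it.

Of the compounds shown here, three sharing one core have been measured in an in vitro functional assay on HEK293-A cells for positive allosteric modulation of metabotropic glutamate receptor 5 (Homo sapiens), read by fluorescence and calcium flux, with a stated time of 140 s; on this read-out lower numbers stand for an effect already at smaller amounts and higher numbers for an effect only at larger amounts of compound. Compound 1 `O=C(C1CCC1)N1CCCC[C@H]1c1nc(-c2cccc(F)c2)no1` gives 700 nM. Compound 2 `O=C(C1CCCCC1)N1CCCC[C@@H]1c1nc(-c2cccc(F)c2)no1` gives 3500 nM. Among the measured compounds shown here, compound 3 `O=C(c1ccc(F)c(F)c1)N1CCCC[C@@H]1c1nc(-c2cccc(F)c2)no1` gives 1400 nM, which places it second highest of the three numbers: compound 1 lies within the scatter of it, while compound 2 sits clearly higher, as the single measured step shows, a 2.5-fold lower number from compound 2 to compound 3 (0.40 log units; beyond the scatter), brought about by 3,4-difluorophenyl in place of cyclohexyl on a carbonyl carbon.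

Compound 4 `O=C(c1ccc(F)cc1)N1CCCC[C@@H]1c1nc(-c2cccc(F)c2)no1` differs from compound 3 by hydrogen in place of fluoro on an aromatic carbon, ortho to the remaining fluoro group and meta to a large group. For the measured compounds named here, no measured step touches this position; the only step in hand swaps the whole group on the carbonyl carbon, a far larger change than removing one fluorine. With nothing to point either way, no step beyond the scatter is expected in this assay. Compound 4 is therefore estimated at about 1400 nM, with a range from 500 nM to 4000 nM. The expected step is no change at the digits printed from compound 3 to compound 4 (within the scatter), a change within the scatter.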

Compound 4, half-maximal effective concentration: 23000 nM
For compound 4 the middle estimate is 16-fold (1.22 log units) below the measured one; measured number above the stated range.
By their numbers in this assay, from the lowest: compounds 1 and 3 (each within the scatter of the next); then compound 2; then compound 4.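

In this assay, this single fluorine on the amide aryl group carries far more weight than its size as a change suggests, since losing it gives a 16-fold higher number from compound 3 to compound 4 (1.22 log units; beyond the scatter), a larger step than the swap of the whole group on the carbonyl carbon that separates compound 2 from compound 3. It also reverses the outcome of that swap: with 4-fluorophenyl in place of cyclohexyl, the result is a 6.6-fold higher number from compound 2 to compound 4 (0.82 log units; beyond the scatter), whereas the 3,4-difluorophenyl group gave a 2.5-fold lower number from compound 2 to compound 3 (0.40 log units; beyond the scatter), so an aryl group on the carbonyl carbon is not by itself better or worse than cyclohexyl here. Nothing available explains why this fluorine matters so much.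

The compounds shown leave open whether fluorine is specifically needed at this place or whether chlorine, a methyl group or a nitrile would serve as well. They also leave open what happens when the remaining fluoro group is removed, as in a plain phenyl group.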